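A few compounds are considered here, and "the series" means these few. Any claim that something is new, unique, unknown or untested is made for them only; others in the source may bear on it.

Measured so far in a functional assay on the whole organism (B cells) with Mus musculus as the target; a higher number here means a larger maximal response, a lower number a smaller maximal response:
compound 1 `C=CCN1C(=C(C(=O)OCC)C(=O)OCC)N([C@H]2OC(CO)[C@H]3OC(C)(C)O[C@H]32)c2cc(N)nc(O)c21` gives 0%
compound 2 `C=CCn1c(=O)n(Cc2ccccc2)c2nc(N)nc(O)c21` gives 25%
compound 3 `Nc1nc(O)c2c(n1)n(C1OC(CO)[C@@H](O)[C@H]1O)c(=O)n2Cc1ccc(Cl)c(Cl)c1` gives 55%

Compound 2 stands second of the three numbers. Compound 1 lies beyond the scatter below it, and compound 3 lies beyond the scatter above it, so the order of all three holds. The three compounds differ in more than one place from each other, so no single step can be read from any pair; only the bare values are known.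

Compound 4 `C=CCn1c(=O)n(CCCC)c2nc(N)nc(O)c21` is the next compound to be measured. It differs from compound 2 in one place: propyl in place of phenyl on a saturated chain carbon bound to an aromatic nitrogen. Read one bond further out, the same change is benzyl to butyl; an aromatic ring of carbon only leaves and a plain chain of three carbon enters, with no change in donors, acceptors or charge.

Among the compounds with values here, no measured step of this kind is at hand, so the expectation rests on compound 2 alone. The step of a number 10 percentage points lower from compound 2 to compound 4 (within the scatter) in this assay is expected to be small and downward, near the edge of the scatter, since compound 2 gives 25% and little room for a large fall remains. Compound 4 is accordingly expected to reach about 15% in this assay, within a range of 0% to 40%.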

Compound 4, largest response reached (reported as maximal response), in percent of the reference or control that the assay uses: 77%
For compound 4 the middle estimate is 62 percentage points below the measured one; the whole stated range lies below it.
By their numbers in this assay, from the lowest: compound 1; then compound 2; then compound 3; then compound 4.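

In this assay, within the data shown here, propyl in place of phenyl on a saturated chain carbon bound to an aromatic nitrogen gives a number 52 percentage points higher from compound 2 to compound 4 (beyond the scatter) and is a large step, the first one-place comparison; the earlier compounds differ from each other in more than one place and showed nothing about any single position. At least for this pair, the six-membered aromatic ring of carbon only is not required for a response at this place, and the plain chain of the butyl group, read one bond further out, gives the greater maximal response with donors, acceptors and net charge unchanged. No measurement at hand bears on the reason for this step.

Still open, on these data alone, is whether the response at this place depends on chain length or shape, as a longer chain such as hexyl, a branched chain such as isobutyl, or a chain ending in an amine or a carboxylic acid would show. Also open, as far as these compounds go, is whether benzyl to butyl has a step of similar size on the core of compound 3, which carries a sugar and a dichlorobenzyl group, since a single pair cannot show how far this change carries over to other members.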